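Acetyl to methyl on the ring nitrogen: cytotoxicity outlook

The compounds below may be only part of what the source reports. "The series", "measured", "known", "first", "only" and "open" are said of these compounds alone.

Three members of the series have been run in an ADME assay on MT4 cells (Homo sapiens) for cytotoxicity, read by MTT assay, with a stated time of 4 days; a higher number here means that more compound is tolerated, a lower number that less compound is tolerated. Compound 1 `CC(=O)Nc1c(C)c(C(OC(C)(C)C)C(=O)O)c(-c2ccc(C)c(C)c2)c(C)c1-c1ccc(C)c(C)c1` gives 19000 nM in this assay. Compound 2 `Cc1ccc(-c2c(C)c(-c3ccc(Cl)cc3)c(C(OC(C)(C)C)C(=O)O)c(C)c2NS(C)(=O)=O)cc1C` gives 26000 nM and compound 3 `Cc1ccc(-c2c(C)c(-c3ccc4c(c3)CCCO4)c(C(OC(C)(C)C)C(=O)O)c(C)c2NS(C)(=O)=O)cc1C` gives 28000 nM; the two gaps from compound 1 are within the scatter, so the three numbers cannot be ordered.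

Compound 4 `CNc1c(C)c(C(OC(C)(C)C)C(=O)O)c(-c2ccc(C)c(C)c2)c(C)c1-c1ccc(C)c(C)c1` differs from compound 1 in one place: methyl in place of acetyl on a nitrogen on an aromatic ring.

Among the compounds with values here, the only measured step, a 1.1-fold higher number from compound 2 to compound 3 (0.03 log units; within the scatter), is a swap of an aryl group elsewhere on the shared core and does not touch the nitrogen. Within the data shown here, no measured pair changes the group on that nitrogen, so the data give no direct guide for the acetyl to methyl exchange. Among the measured compounds shown here, with every step so far inside the scatter, no move beyond the scatter is expected for compound 4, in either direction: a 1.1-fold higher number from compound 1 to compound 4 (0.02 log units; within the scatter) is the expected step.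

Compound 4 is therefore estimated at 20000 nM in this assay, with an expected range from 8000 nM to 50000 nM.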

Compound 4, half-maximal cytotoxic concentration: 8800 nM
The estimate for compound 4 lay 2.3-fold (0.36 log units) above the measured number; low and high end bracket the measured number.
By their numbers in this assay, from the lowest: compound 4; then compounds 1, 2 and 3 (each within the scatter of the next).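

In this assay, methyl in place of acetyl on a nitrogen on an aromatic ring gives a 2.2-fold lower number from compound 1 to compound 4 (0.33 log units; beyond the scatter), the only step shown that lies beyond the scatter, though a modest one. The group on this nitrogen can therefore move the read-out towards less compound being tolerated, which the earlier aryl swap, a 1.1-fold higher number from compound 2 to compound 3 (0.03 log units; within the scatter), could not show. Nothing available bears on the reason for this step.

As far as these compounds go, how a free amine, an ethyl group or a longer alkyl chain on this nitrogen would read remains open, so the acetamido to methylamino step cannot yet be placed in any wider trend. From the compounds shown here alone, whether the step carries over to the other aryl groups of compound 2 and compound 3 is also open.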